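Added aromatic methyl beside the core: compound 4

The source may report more compounds than this note shows. Statements on the series, on what has been measured and on what is new or still open speak of the compounds shown alone.

Among the compounds with values here, compound 1 `Cc1ccc2[nH]c(-c3cccc(C)n3)nc2c1` gives 42% in a functional assay on the whole organism with Rattus norvegicus as the target, read by paw edema, with a stated time of 3 h, at a dose of 100 mg/kg by the oral route (a lower number here means less inhibition, a higher number more inhibition at the dose given (going by the name of the read-out)), the highest of the three numbers measured so far. Compound 2 `COc1ccc2[nH]c(-c3cccc(C)n3)nc2c1` gives 40%; the step of a number 2 percentage points lower from compound 1 to compound 2 (within the scatter) lies within the scatter. Compound 3 `CCc1cccc(-c2nc3cc(C)ccc3[nH]2)n1` gives 10%; the step of a number 32 percentage points lower from compound 1 to compound 3 (beyond the scatter) is large. Compound 4 `Cc1ccc2[nH]c(-c3ccc(C)c(C)n3)nc2c1` has not been measured; it differs from compound 1 by methyl in place of hydrogen on an aromatic carbon. Neither measured step matches this change exactly: the step of a number 2 percentage points lower from compound 1 to compound 2 (within the scatter) exchanges one substituent on an aromatic carbon for another, while the step of a number 32 percentage points lower from compound 1 to compound 3 (beyond the scatter) adds a methyl on a saturated chain carbon rather than on the ring. Within the data shown here, the only added methyl, in compound 3, came with a large loss of inhibition; the only change on an aromatic carbon, in compound 2, came with no change beyond the scatter. A moderate fall is therefore expected for compound 4, a number 10 percentage points lower from compound 1 to compound 4 (within the scatter), with wide uncertainty. Compound 4 is estimated at 32%, between 14% and 50%.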

Compound 4, a percentage reported as inhibition, in the whole organism at one dose (the size of the read-out at that dose, not a potency): -19%
Estimate against measurement, compound 4: 51 percentage points above; the measured number lies below the stated range.
By their numbers in this assay, from the lowest: compound 4; then compound 3; then compounds 2 and 1 (each within the scatter of the next).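

On this aromatic carbon, ortho to a methyl group and two atoms from the ring nitrogen, adding one methyl is far from neutral in this assay: the step is a number 61 percentage points lower from compound 1 to compound 4 (beyond the scatter), and the negative value records no inhibition at the dose given. The within-scatter result at another aromatic carbon, a number 2 percentage points lower from compound 1 to compound 2 (within the scatter), therefore does not carry over to this position, while both added methyls in the series, including a number 32 percentage points lower from compound 1 to compound 3 (beyond the scatter), lower the number beyond the scatter. No measurement shown gives a reason for the size of this loss.

As far as these compounds go, whether the loss belongs to methyl alone or to any substituent on this carbon remains open. A fluorine, a hydroxyl group, an amine or a carboxylic acid at the same place would test that.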